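Swapping the acetyl of compound 2 for a larger ring group

A few compounds are considered here, and "the series" means these few. Any claim that something is new, unique, unknown or untested is made for them only; others in the source may bear on it.

In a functional assay on HCT-116 cells (Homo sapiens) for inhibition, read by colorimetric assay, with a stated time of 3 days (on this read-out lower numbers stand for stronger inhibition and higher numbers for weaker inhibition), compound 1 (`O=C(CCCCNC(=O)C(O)(O)C(F)(F)F)Nc1ccccc1`) gives 20300 nM. Compound 2 (`CC(=O)C(=O)NCCCCC(=O)Nc1ccccc1`) gives no number, only a limit of > 100000 nM. Compound 2 is therefore placed solely by the limit of > 100000 nM in this assay, at which 1 of the 2 values shown sits.

Compound 3 (`O=C(CCCCNC(=O)c1cc(=O)c(O)co1)Nc1ccccc1`) keeps the rest of compound 2 and differs at a single place: a group of 8 heavy atoms (5 carbon, 3 oxygen; one six-membered aromatic ring with 1 hetero atom) in place of a group of 3 heavy atoms (2 carbon, 1 oxygen; no ring), on a carbonyl carbon. The acetyl group leaves, and the incoming group carries one six-membered aromatic ring with 1 hetero atom.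

Going by the values given here, one measured step bears on this change, at the same kind of carbonyl carbon: an at least 4.9-fold higher number from compound 1 to compound 2 (0.69 log units; beyond the scatter). It shows that the group at this place can shift the read-out beyond the scatter, but its incoming group differs from that of compound 3, so it is only a loose guide to size. Among the compounds with values here, the one firm number nearby is that of compound 1 at 20300 nM. A modest move towards a lower number is therefore expected, and a second limit remains possible. The estimated change is an at least 3.3-fold lower number from compound 2 to compound 3 (0.52 log units; beyond the scatter). In this assay the estimate for compound 3 is 30000 nM, with an expected range of 8000 nM to 100000 nM.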

Compound 3, half-maximal inhibitory concentration: > 100000 nM
Compound 3 was reported as a limit; the forecaster's own chance of this, stated with the estimate: 30%; at least 3.3-fold (0.52 log units) between middle value and limit.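

Compound 3, like compound 2, is reported in this assay only as a limit and not as a number, so the step between them cannot be read and the two cannot be ranked. Going by these compounds alone, the one readable comparison is with compound 1, where the ring-bearing group replaces the 2,2,2-trifluoro-1,1-dihydroxyethyl group on the same kind of carbonyl carbon: an at least 4.9-fold higher number from compound 1 to compound 3 (0.69 log units; beyond the scatter). What compound 3 adds is that a much larger group at this place, carrying a six-membered aromatic ring and more hydrogen-bond donors and acceptors than acetyl, does not by itself bring a measurable value, and compound 1 remains the only one of the three with a firm number: the limit of > 100000 nM in this assay, at which 2 of the 3 values shown sit.

Going by these compounds, how far compound 2 and compound 3 lie past that limit, and in what order, stays open. Also open is whether a carboxylic acid, an amine or a longer chain on this carbonyl carbon would give a firm number, and with a single measured value the compounds shown cannot tell which part of the group in compound 1 matters.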